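The source may report more compounds than this note shows. Statements on the series, on what has been measured and on what is new or still open speak of the compounds shown alone.

Measured compounds:
Compound 1, `C[C@@H](NC(=O)[C@H](CCCNC(=N)N)NC(=O)c1ccc(CN(Cc2ccc(F)cc2)Cc2cccnc2)cc1)c1cccc2ccccc12`: 6%
Compound 2, `C[C@@H](NC(=O)[C@H](CCCNC(=N)N)NC(=O)c1ccc(CN(Cc2ccccn2)C(=O)c2ccc(F)cc2)cc1)c1cccc2ccccc12`: 3%

In an assay on Jurkat cells for displacement of a labelled ligand from C-X-C chemokine receptor type 4 (Homo sapiens), tested at 10 uM (on this read-out higher numbers stand for more inhibition at the one concentration tested (going by the name of the read-out) and lower numbers for less inhibition), compound 2 gives 3% and compound 1 gives 6%; the two numbers lie within the usual scatter of each other, so compound 2 stands together with compound 1 at the low end of the scale. Compound 3, `C[C@@H](NC(=O)[C@H](CCCNC(=N)N)NC(=O)c1ccc(CN(Cc2cccnc2)C(=O)c2ccc(F)cc2)cc1)c1cccc2ccccc12`, is not yet measured. It differs from compound 2 in one place: pyridin-3-yl in place of pyridin-2-yl on a saturated chain carbon bound to an amide-type nitrogen. Among the measured compounds shown here, no measured step of this kind is available, so a change beyond the scatter is not expected in either direction. The step expected in this assay is a number 2 percentage points higher from compound 2 to compound 3 (within the scatter). Compound 3 is expected to give about 5%, within -5% to 15%.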

Compound 3, a percentage reported as inhibition, at one concentration (the size of the read-out at that concentration, not a potency): 11%
For compound 3 the middle estimate is 6 percentage points below the measured one; the measured number falls inside the stated range.
By their numbers in this assay, from the lowest: compounds 2, 1 and 3 (each within the scatter of the next).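

In this assay, pyridin-3-yl in place of pyridin-2-yl on a saturated chain carbon bound to an amide-type nitrogen gives a number 8 percentage points higher from compound 2 to compound 3 (within the scatter), so this swap does not clearly change the read-out. (4-Fluorophenyl)carbonyl in place of 4-fluorobenzyl on an amine nitrogen gives a number 5 percentage points higher from compound 1 to compound 3 (within the scatter), so this change does not separate the compounds either. Nothing available here explains these results. Still open, on these data alone, is whether an amine or a carboxylic acid on the pyridine ring, or a longer chain in place of the methyl link to that ring, would shift the number beyond the scatter.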